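The compounds below may be only part of what the source reports. "The series", "measured", "known", "first", "only" and "open" are said of these compounds alone.

Compound 1 `CCCCCCCCCCOc1cc(OCCCCCCCCCC)cc(OCCCCCC(=O)N(c2ccc(C(=O)OC)cc2)c2ccc(C(=O)OC)c(C(=O)OC)c2)c1` holds the higher of the two numbers available: in an assay on isolated protein for binding affinity to P-selectin (Homo sapiens), read by ELISA, tested at 500 uM (a lower number here means less inhibition, a higher number more inhibition at the concentration tested (going by the name of the read-out)), compound 1 gives 90%, while compound 2 `O=C(O)c1ccc(N(C(=O)CCCCCBr)c2ccc(C(=O)O)cc2)cc1` gives 12%, a gap that lies well beyond the usual scatter. Compound 3 `CCCCCCCCCCOc1cc(OCCCCCCCCCC)cc(OCCCCCC(=O)N(c2ccc(C(=O)OC)cc2)c2ccc(C(=O)OC)cc2)c1` differs from compound 1 in one place, (hydrogen in place of methoxycarbonyl on an aromatic carbon). Within the data shown here, with no measured pair of this kind to draw on, the step in this assay from compound 1 to compound 3 is expected to be small and downward, at most slightly beyond the scatter, namely a number 10 percentage points lower from compound 1 to compound 3 (within the scatter). Compound 3 is therefore estimated to give 80%, within a range from 55% to 95%.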

Compound 3, a percentage reported as inhibition, at one concentration (the size of the read-out at that concentration, not a potency): 16%
Beside the measured number, compound 3's estimate is 64 percentage points above it; measured number outside the range, below it.
By their numbers in this assay, from the lowest: compounds 2 and 3 (each within the scatter of the next); then compound 1.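

Hydrogen in place of methoxycarbonyl on this aromatic carbon, ortho to a methoxycarbonyl group and meta to a large group, gives a number 74 percentage points lower from compound 1 to compound 3 (beyond the scatter) in this assay. This single position therefore matters greatly: the inhibition seen with compound 1 is largely lost when this one group leaves. Nothing available explains why this group has so large an effect. On these data alone, it remains open whether a carboxylic acid, a primary amide or a methyl group on this carbon would retain the inhibition, or whether only methoxycarbonyl does so.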